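The source may report more compounds than this note shows. Statements on the series, on what has been measured and on what is new or still open speak of the compounds shown alone.

Working notes on the series.

The shared core is a styryl-linked bicyclic lactam; the compounds differ only in the substituent on the oxygen attached to the pendant aromatic ring and in where that oxygen sits on the ring. Compound 1 `CC(=O)Oc1ccccc1/C=C/c1nc2ccccc2c(=O)[nH]1` carries an acetyl on that oxygen, and in a functional assay on HCT-116 cells (Homo sapiens) for antiproliferative activity, with a stated time of 72 h (a lower number here means a stronger inhibitor, a higher number a weaker inhibitor), compound 1 gives 17200 nM. Compound 3 `COc1ccccc1/C=C/c1nc2ccccc2c(=O)[nH]1` is its methyl counterpart, and in this assay compound 3 gives 1460 nM. The change between them, (methyl in place of acetyl on an oxygen on an aromatic ring), produced a 12-fold lower number from compound 1 to compound 3 (1.07 log units; beyond the scatter).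

Compound 2 `CC(=O)Oc1cccc(/C=C/c2nc3ccccc3c(=O)[nH]2)c1` keeps the acetyl but has the oxygen at a different position of the ring; the difference between the two cores of compound 1 and compound 2 is not broken down here. In this assay compound 2 gives 9290 nM, which sits within the scatter of compound 1 and beyond it relative to compound 3.

Compound 4 `COc1cccc(/C=C/c2nc3ccccc3c(=O)[nH]2)c1` is the methyl counterpart of compound 2. The change from compound 2 to compound 4, (methyl in place of acetyl on an oxygen on an aromatic ring), is the same change as that from compound 1 to compound 3: the leaving and entering groups and the place lines match word for word. On that single precedent, the step from compound 2 to compound 4 is expected to be about a 12-fold lower number from compound 2 to compound 4 (1.06 log units; beyond the scatter), because compound 1 to compound 3 gave a 12-fold lower number from compound 1 to compound 3 (1.07 log units; beyond the scatter). Going by the values given here, with only one example of the change, the range is kept wide. Compound 4 is therefore estimated at 800 nM in this assay, with an expected span from 250 nM to 2600 nM.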

Compound 4, half-maximal inhibitory concentration: > 25000 nM
Compound 4 gave a limit, no number (the forecaster's own chance of this, stated with the estimate: 2%); middle value at least 31-fold (1.49 log units) away from the limit.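

Compound 4 gives > 25000 nM in this assay, which is a limit of the assay and not a number: the limit of > 25000 nM in this assay, at which 1 of the 4 values shown sits.

Even so, the direction of the new step can be read, an at least 2.6-fold higher number from compound 2 to compound 4 (0.42 log units; beyond the scatter), and methyl in place of acetyl does not carry over from the core of compound 1 to the core of compound 2: the same change on two cores in this assay, a 12-fold lower number (1.07 log units; beyond the scatter) from compound 1 to compound 3 and an at least 2.6-fold higher number (0.42 log units; beyond the scatter) from compound 2 to compound 4, at least 31-fold (1.50 log units) apart, beyond the scatter of two such steps

This shows that, for these two pairs, the result of acetoxy to methoxy on one core is a poor guide to its result on the other, but it rests on one pair per core, gives only a bound for the step on the core of compound 2, and does not show why the two cores part or which would be the more usual case in a wider series.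

The compounds shown leave open how a hydroxyl, or a longer chain such as ethyl or propyl, on that same oxygen would read on each core, and whether either would follow compound 3 or compound 4. They also leave open whether an amine in place of that oxygen would show the same split between the two cores.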